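A few compounds are considered here, and "the series" means these few. Any claim that something is new, unique, unknown or untested is made for them only; others in the source may bear on it.

Working notes on the series. The shared core stays fixed and only the amide arm varies: compound 1 `CCN(CC)c1cc2[nH]c(C3CCCCC3)nc2cc1NC(=O)c1ccc(OC(F)(F)F)cc1`, compound 2 `CCN(CC)c1cc2[nH]c(C3CCCCC3)nc2cc1NC(=O)c1ccc(F)cc1F` and compound 3 `CCCCCC(=O)Nc1cc2nc(C3CCCCC3)[nH]c2cc1N(CC)CC`. In an ADME assay on Vero cells (Chlorocebus sabaeus) for cytotoxicity, read by resazurin assay, with a stated time of 3 days (a lower number here means a stronger inhibitor, a higher number a weaker inhibitor), compound 1 gives > 100 ug/mL, a limit of the assay rather than a number. Compound 2 likewise reaches only the limit > 100 ug/mL in this assay. Accordingly a step that the two limits leave unreadable from compound 1 to compound 2 cannot be sized, given (the limit of > 100 ug/mL in this assay, at which 2 of the 3 values shown sit). Compound 3 stands nowhere on these numbers: in this assay compound 3 gives "not determined" (no result reported), so no anchor exists for the next step. Compound 4 `CCCOCC(=O)Nc1cc2nc(C3CCCCC3)[nH]c2cc1N(CC)CC` differs from compound 3 by propoxy in place of butyl on a saturated chain carbon bound to a carbonyl carbon. For the measured compounds named here, no measured step bears on this change, and the one comparison available is itself unreadable. With two of three results at the limit, compound 4 is expected to sit in the same region in this assay, estimated at 120 ug/mL with a range from 60 ug/mL to 250 ug/mL.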

Compound 4, half-maximal inhibitory concentration: > 100 ug/mL
Compound 4: no number, only a limit; the forecaster's own chance of this, stated with the estimate: 75%; the middle value does not contradict the limit.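

No step can be read in this assay among compound 1, compound 2 and compound 4, as each gives only a limit: the limit of > 100 ug/mL in this assay, at which 3 of the 4 values shown sit.

The compounds shown leave open whether any change in the amide arm shifts the result in this assay.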